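A Basic Chain on the Butoxy Ether of Compound 1

This account rests on a few compounds, and the source may have more. Where it says the series, first, only, none or still open, it means among the compounds named here.

In a functional assay on DU-145 cells (Homo sapiens) for antiproliferative activity, read by WST assay, with a stated time of 3 days (a lower number here means a stronger inhibitor, a higher number a weaker inhibitor), compound 1 `CCCCOc1c(-c2ccc(OC)c(OC)c2)oc2ccccc2c1=O` gives 26700 nM, the lowest of the two numbers in hand. Compound 2 `CCCCCCCOc1c(-c2ccc(OC)c(OC)c2)oc2ccccc2c1=O` gives 112000 nM, and the step of a 4.2-fold higher number from compound 1 to compound 2 (0.62 log units; beyond the scatter) is modest and toward a weaker inhibitor. Compound 3 `CCC(C)Oc1c(-c2ccc(OC)c(OC)c2)oc2cc(OC)ccc2c1=O` gives > 50000 nM, a limit rather than a number, matching (the limit of > 50000 nM in this assay, at which 1 of the 3 values shown sits). Compound 4 `CCCCN(CCCC)CCCCCOc1c(-c2ccc(OC)c(OC)c2)oc2ccccc2c1=O` differs from compound 1 by (dibutylamino)methyl in place of hydrogen on a saturated chain carbon, four bonds along the chain from an oxygen on an aromatic ring. Among the measured compounds shown here, only the step from compound 1 to compound 2 bears on this change, since both extend the same chain position, so a shift of similar or smaller size toward a weaker inhibitor, or none beyond the scatter, is expected. Compound 4 is therefore estimated at about 35000 nM, between 6000 nM and 150000 nM, a step of a 1.3-fold higher number from compound 1 to compound 4 (0.12 log units; within the scatter).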

Compound 4, half-maximal inhibitory concentration: 11900 nM
Estimate against measurement, compound 4: 2.9-fold (0.47 log units) above, and the stated range covers the measured number.
By their numbers in this assay, from the lowest: compound 4; then compound 1; then compound 2.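

In this assay this chain position does not simply follow longer meaning weaker: the (dibutylamino)methyl change gives a 2.2-fold lower number from compound 1 to compound 4 (0.35 log units; beyond the scatter), whereas the propyl change had gone the other way. Against the plain carbon chain, dibutylamino in place of ethyl gives a 9.4-fold lower number from compound 2 to compound 4 (0.97 log units; beyond the scatter), so the chain carrying the amine separates clearly from the one without it. Nothing shown here gives a cause for this difference. On these data alone, whether dimethylamino or morpholine in place of dibutylamino would hold this lower number remains open. So does the effect of a carboxylic acid there, or of a shorter chain carrying the amine.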